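A Methoxymethyl Branch on the Chain at the Aromatic Nitrogen

A few compounds are considered here, and "the series" means these few. Any claim that something is new, unique, unknown or untested is made for them only; others in the source may bear on it.

Two measured compounds share one core and differ only in the ring on the amide-type nitrogen. Compound 1 `CCn1cc(C(=O)C(=O)Nc2ccnc(OC)c2)c2ccccc21` gives 4180 nM in a functional assay on FaDu cells (Homo sapiens) for cytotoxicity, read by MTT assay, with a stated time of 72 h; a lower number here means that less compound is tolerated, a higher number that more compound is tolerated. Compound 2 `CCn1cc(C(=O)C(=O)Nc2ccc(OC)nc2)c2ccccc21` gives 219 nM in this assay. The step of a 19-fold lower number from compound 1 to compound 2 (1.28 log units; beyond the scatter) separates them, so on these two numbers compound 2 stands at the lower end, the less tolerated of the pair.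

Compound 3 `COCC(C)n1cc(C(=O)C(=O)Nc2ccc(OC)nc2)c2ccccc21` has not yet been measured. It differs from compound 2 by methoxymethyl in place of hydrogen on a saturated chain carbon bound to an aromatic nitrogen and a saturated chain carbon; cut one bond further out, the change reads ethyl to 1-(methoxymethyl)ethyl, while the ring on the amide-type nitrogen is kept. Within the data shown here, no measured step touches this place: the single known step, a 19-fold lower number from compound 1 to compound 2 (1.28 log units; beyond the scatter), concerns the ring on the amide-type nitrogen and says nothing about the chain on the aromatic nitrogen. With nothing to lean on, the step of a 1.4-fold higher number from compound 2 to compound 3 (0.14 log units; within the scatter) is expected to be small, most likely within the scatter, in either direction. Compound 3 is estimated at 300 nM in this assay, with a range from 90 nM to 1500 nM.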

Compound 3, concentration lethal to 50% of the cells in the FaDu assay: 12 nM
The estimate for compound 3 lay 25-fold (1.40 log units) above the measured number, outside the stated range (below it).
By their numbers in the FaDu assay, from the lowest: compound 3; then compound 2; then compound 1.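

The chain on the aromatic nitrogen proves to be a sensitive place in the FaDu assay: an 18-fold lower number from compound 2 to compound 3 (1.26 log units; beyond the scatter), so a second site on the shared core now carries a large step, alongside the ring on the amide-type nitrogen, where a 19-fold lower number from compound 1 to compound 2 (1.28 log units; beyond the scatter). The entering methoxymethyl has only 3 heavy atoms, no ring and 1 hydrogen-bond acceptor, so a small addition on a saturated chain carbon bound to an aromatic nitrogen and a saturated chain carbon is enough to give this step. In a physicochemical assay for solubility, in phosphate buffer, at pH 7.4 (a lower number here means a less soluble compound, a higher number a more soluble compound), compound 2 gives 10000 nM and compound 3 gives 40000 nM. The same change also comes with a more soluble compound in the physicochemical assay, a shift that says nothing by itself about the lower number in the FaDu assay: the measured solubility of compound 2, 10000 nM, and of compound 3, 40000 nM, a 4.0-fold higher number (0.60 log units; beyond the scatter)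

The compounds shown do not separate the branch from its ether oxygen, a question that an isopropyl group, which has the branch without the oxygen, or an unbranched 2-methoxyethyl chain, which has the oxygen without the branch, would address. They also leave open whether 1-(methoxymethyl)ethyl would give a step of this size with the 2-methoxypyridin-4-yl ring of compound 1, and how a longer chain or an amine at this place would behave.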